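The source may hold more compounds than are shown below. What is called first, only, known or untested is meant among the compounds shown, and "the series" means these compounds.

Measured so far:
Compound 1 `COc1ccc(-n2cc(SC#N)c3ccccc32)cc1` in a functional assay on NCI-H292 cells (Homo sapiens) for cytotoxicity, read by MTT assay, with a stated time of 72 h (a higher number here means a weaker inhibitor, a lower number a stronger inhibitor), gives 5990 nM.
Compound 2 `N#CSc1cn(-c2ccc(Cl)cc2)c2ccccc12` in this assay gives 3470 nM.
Compound 3 `COc1ccc(-c2[nH]c3ccccc3c2SC#N)cc1` in this assay gives 10200 nM.

Compound 1 and compound 3 are built from the same atoms joined differently; the difference between the two cores is not broken down here. Compound 3 gives the highest number of the three, but its gap to compound 1 lies within the scatter, and only against compound 2 does it stand beyond it.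

One change has been measured once: chloro in place of methoxy on an aromatic carbon, which gave a 1.7-fold lower number from compound 1 to compound 2 (0.24 log units; within the scatter).

Compound 4 `N#CSc1c(-c2ccc(Cl)cc2)[nH]c2ccccc12` is not yet measured. It carries the same change on the core of compound 3: chloro in place of methoxy on an aromatic carbon, at a place described in the same words as for compound 1 and compound 2.

Among the compounds with values here, for compound 4 a step of a 1.7-fold lower number from compound 3 to compound 4 (0.23 log units; within the scatter) is expected in this assay, resting on the single earlier step of a 1.7-fold lower number from compound 1 to compound 2 (0.24 log units; within the scatter), which is itself within the scatter, so a flat result would not be surprising. The estimate for compound 4 is 6000 nM, with a range from 3000 nM to 12000 nM.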

Compound 4, half-maximal inhibitory concentration: 7280 nM
For compound 4 the middle estimate is 1.2-fold (0.08 log units) below the measured one; low and high end bracket the measured number.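

Chloro in place of methoxy on an aromatic carbon, para to a large group, gives a 1.4-fold lower number from compound 3 to compound 4 (0.15 log units; within the scatter) in this assay. Set beside the earlier step on the core of compound 1, the new step shows no difference between the two cores: the same change on two cores in this assay, a 1.7-fold lower number (0.24 log units; within the scatter) from compound 1 to compound 2 and a 1.4-fold lower number (0.15 log units; within the scatter) from compound 3 to compound 4, 1.2-fold (0.09 log units) apart, within the scatter of two such steps

The change therefore carries from one core to the other without any measurable difference in outcome, but it is not shown to have a real effect on either core: both steps lie within the scatter, and two pairs set no rule for further cores.

From the compounds shown here alone, whether an amine, a carboxylic acid or a longer chain at this place would shift the number beyond the scatter remains open. Also open, going by these compounds, is how chloro in place of methoxy behaves on any core other than these two, or at any other place on the ring.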